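Fluoro for Nitro on a Second Core: Cytotoxicity Expectation

A few compounds are considered here, and "the series" means these few. Any claim that something is new, unique, unknown or untested is made for them only; others in the source may bear on it.

Compound 1 `O=C(CCN1CCN(c2ccc([N+](=O)[O-])cc2)CC1)c1csc2ccc(F)cc12` and compound 2 `O=C(CCN1CCN(c2ccc(F)cc2)CC1)c1csc2ccc(F)cc12` share one core and differ only in the change (fluoro in place of nitro on an aromatic carbon). In an ADME assay on Vero cells (Chlorocebus sabaeus) for cytotoxicity, with a stated time of 72 h (on this read-out higher numbers stand for weaker inhibition and lower numbers for stronger inhibition), compound 1 gives 554000 nM and compound 2 gives 759000 nM; that step is a 1.4-fold higher number from compound 1 to compound 2 (0.14 log units; within the scatter). Compound 3 `O=C(CCN1CCN(c2ccc([N+](=O)[O-])cc2)CC1)c1ccc2ccccc2c1` carries the nitro group on a different core, and the difference between the two cores is not broken down here. In this assay compound 3 gives 74300 nM, the lowest of the three numbers, with its nearest neighbour, compound 1, a step away that lies beyond the scatter. Compound 4 `O=C(CCN1CCN(c2ccc(F)cc2)CC1)c1ccc2ccccc2c1` arises from compound 3 by fluoro in place of nitro on an aromatic carbon, the same change as before. Because the earlier step of a 1.4-fold higher number from compound 1 to compound 2 (0.14 log units; within the scatter) lay within the scatter, the step from compound 3 is expected to be small as well, a 1.3-fold higher number from compound 3 to compound 4 (0.13 log units; within the scatter). Compound 4 is therefore estimated at 100000 nM in this assay, between 40000 nM and 250000 nM.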

Compound 4, half-maximal inhibitory concentration: 103000 nM
The estimate for compound 4 lay 1.0-fold (0.01 log units) below the measured number, within the range that was stated.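

In this assay, fluoro in place of nitro gives a 1.4-fold higher number from compound 3 to compound 4 (0.14 log units; within the scatter), so this step stays as small on the second core as on the first. Set side by side, the two steps agree: the same change on two cores in this assay, a 1.4-fold higher number (0.14 log units; within the scatter) from compound 1 to compound 2 and a 1.4-fold higher number (0.14 log units; within the scatter) from compound 3 to compound 4, 1.0-fold (0.01 log units) apart, within the scatter of two such steps This shows that, in this small series, the change can be carried between these two cores with little effect on the cytotoxicity read-out, but two cores cannot establish a general rule, and the result does not extend to other assays.

From the compounds shown here alone, whether an amine or a carboxylic acid in the same place would also leave the number within the scatter remains open. So does the size of this change on any further core.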